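Adding a second fluoro to compound 3

The compounds below may be only part of what the source reports. "The series", "measured", "known", "first", "only" and "open" are said of these compounds alone.

compound 1 `CC(C)[C@H](NC(=O)COc1cccc2ccccc12)C(=O)N[C@@H](CC(=O)O)C(=O)COc1ccccc1`: 14000 nM
compound 2 `CC(C)[C@H](NC(=O)COc1cccc2ccccc12)C(=O)N[C@@H](CC(=O)O)C(=O)COc1ccccc1F`: > 100000 nM
compound 3 `CC(C)[C@H](NC(=O)COc1cccc2ccccc12)C(=O)N[C@@H](CC(=O)O)C(=O)COc1cccc(F)c1`: > 100000 nM

Among the compounds with values here, in a functional assay on Jurkat cells (Homo sapiens) (on this read-out lower numbers stand for stronger inhibition and higher numbers for weaker inhibition), compound 1 gives 14000 nM, the only true number of the three. Compound 2 gives > 100000 nM, which is a limit of the assay and not a number. Compound 3 gives > 100000 nM, which is also a limit. Compound 2 and compound 3 thus share (the limit of > 100000 nM in this assay, at which 2 of the 3 values shown sit), so compound 3 has no exact position.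

Compound 4 `CC(C)[C@H](NC(=O)COc1cccc2ccccc12)C(=O)N[C@@H](CC(=O)O)C(=O)COc1ccc(F)c(F)c1` differs from compound 3 by one change: fluoro in place of hydrogen on an aromatic carbon. This is fluoro in place of hydrogen on an aromatic carbon, and it turns 3-fluorophenoxy into 3,4-difluorophenoxy.

Two measured steps of the same kind bear on it, an at least 7.1-fold higher number from compound 1 to compound 2 (0.85 log units; beyond the scatter) and an at least 7.1-fold higher number from compound 1 to compound 3 (0.85 log units; beyond the scatter). Both ran toward weaker inhibition, so in this assay compound 4 is expected to show no recovery and to stay at or near the limit. Neither step adds a second fluoro to a ring that already carries one, so this expectation remains loose. The step expected is a number no higher from compound 3 to compound 4 (the limit leaves the size open), and no readable size is expected for it. Compound 4 is estimated at 100000 nM, with an expected range from 30000 nM to 300000 nM.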

Compound 4, half-maximal inhibitory concentration: > 100000 nM
Compound 4: a limit, no number; the forecaster's own chance of this, stated with the estimate: 80%; the middle value sits exactly at the limit.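

Compound 4 gives > 100000 nM in this assay, which is a limit of the assay and not a number. A fluoro on this aromatic carbon, ortho to a fluoro group and para to a large group, therefore brings no readable recovery, and the 3,4-difluorophenyl compound joins the two monofluorinated compounds, so that among the compounds shown every fluorinated ring sits at the limit and only the unsubstituted phenyl ring of compound 1 gives a true number; against that compound the change amounts to an at least 7.1-fold higher number from compound 1 to compound 4 (0.85 log units; beyond the scatter). The steps to compound 4 from compound 2 and from compound 3 cannot be read, because those values all rest on one shared limit: the limit of > 100000 nM in this assay, at which 3 of the 4 values shown sit.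

On these data alone, how much weaker than the limit any of the three fluorinated compounds lies remains open, as does whether a lone fluoro para to a large group would behave in the same way. As far as these compounds go, what a chloro, a methyl or a methoxy group would give in place of this hydrogen also stays unknown.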